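Swapping Fluoro for (3-fluorobenzyl)oxy on Compound 1

The compounds below may be only part of what the source reports. "The series", "measured", "known", "first", "only" and "open" are said of these compounds alone.

In a functional assay on A549 cells (Homo sapiens) for inhibition, read by sulforhodamine B assay, with a stated time of 72 h (a higher number here means a weaker inhibitor, a lower number a stronger inhibitor), compound 1 `COc1cc2c(Nc3ccc(F)c(Cl)c3)ncnc2cc1OCCOCCn1ccnc1[N+](=O)[O-]` gives 7640 nM and compound 3 `C#Cc1cccc(Nc2ncnc3cc(OCCOCCn4ccnc4[N+](=O)[O-])c(OC)cc23)c1` gives 6430 nM, so these two sit level. Compound 2 `C#Cc1cccc(Nc2ncnc3cc(OCCCCCn4ccnc4[N+](=O)[O-])c(OC)cc23)c1` is clearly stronger, at 180 nM. Compound 4 `COc1cc2c(Nc3ccc(OCc4cccc(F)c4)c(Cl)c3)ncnc2cc1OCCOCCn1ccnc1[N+](=O)[O-]` alters compound 1 in one place: (3-fluorobenzyl)oxy in place of fluoro on an aromatic carbon. The closest measured change, 3-ethynylphenyl in place of 3-chloro-4-fluorophenyl, touches the same group and gives a 1.2-fold lower number from compound 1 to compound 3 (0.07 log units; within the scatter). The far larger a 36-fold higher number from compound 2 to compound 3 (1.55 log units; beyond the scatter) comes from the chain, elsewhere in the molecule, so it says little here. For the measured compounds named here, no measured step adds a group of this size, so only a small shift, within the scatter, is expected in this assay. The expected change is a 1.5-fold lower number from compound 1 to compound 4 (0.18 log units; within the scatter). Compound 4 is estimated at 5000 nM, with an expected range of 1500 nM to 15000 nM.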

Compound 4, half-maximal inhibitory concentration: 6230 nM
Estimate against measurement, compound 4: 1.2-fold (0.10 log units) below, within the range that was stated.
By their numbers in this assay, from the lowest: compound 2; then compounds 4, 3 and 1 (each within the scatter of the next).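

At this aromatic carbon, ortho to a chloro group, this assay shows a 1.2-fold lower number from compound 1 to compound 4 (0.09 log units; within the scatter) when (3-fluorobenzyl)oxy, with its added aromatic ring, replaces a single fluorine. For the compounds shown here, no earlier step tested a group of this size, and this one shows that the position can carry it with no shift beyond the scatter, at least alongside the chain of compound 1. No measured evidence bears on this result, so it comes with no explanation.

On these data alone, whether an amine or a carboxylic acid at this carbon would leave the number as level stays open. So does whether (3-fluorobenzyl)oxy would behave the same way alongside the chain of compound 2.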